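Swapping a Guanidine Tail for a Benzyl Ester

The compounds below may be only part of what the source reports. "The series", "measured", "known", "first", "only" and "open" are said of these compounds alone.

Compound 1 `N=C(N)NCCC[C@H](NC(=O)CN(c1ncnc2c1ncn2C1CCCCO1)C1CC1)C(=O)OCc1ccccc1` was tested in a functional assay on the whole organism (Tail, strain ICR) with Mus musculus as the target, in the tail flick test, with a stated time of 60 min, at a dose of 25 umol/kg by the oral route (a lower number here means a weaker effect, a higher number a stronger effect of the compound at the dose given), and gave 52.4%, the highest of the three numbers available. Compound 2 `NCCCC[C@H](NC(=O)CN(c1nc(Cl)nc2[nH]cnc12)C1CC1)C(=O)OCc1ccccc1` gave 41.2% in this assay, a number beyond the usual scatter below that of compound 1. Compound 3 `NC(=O)CC[C@H](NC(=O)CN(c1nc(Cl)nc2[nH]cnc12)C1CC1)C(=O)O` gave 38.4% in this assay, again beyond the scatter below compound 1. Compounds 2 and 3 differ from compound 1 in more than one place, so no single step can be read from them.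

Compound 4 `O=C(CN(c1ncnc2c1ncn2C1CCCCO1)C1CC1)N[C@@H](CCC(=O)OCc1ccccc1)C(=O)OCc1ccccc1` has not yet been measured. Compared with compound 1, the change is a group of 10 heavy atoms (8 carbon, 2 oxygen; one six-membered aromatic ring of carbon only) in place of a group of 5 heavy atoms (2 carbon, 3 nitrogen; no ring), on a saturated chain carbon, three bonds along the chain from an amide-type nitrogen and a carbonyl carbon. Among the compounds with values here, no measured pair in this set shows a change of this kind, so the size of the step has to be guessed from the spread of the three numbers alone. A modest decrease in this assay is expected, because compound 1 gives 52.4%, the highest of the three numbers, and compounds 2 and 3 both lie beyond the scatter from it. For compound 4, a value of 40% is estimated in this assay, within a range of 25% to 55%. This estimate means a step of a number 12.4 percentage points lower from compound 1 to compound 4 (beyond the scatter) that is expected to reach just beyond the scatter.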

Compound 4, a percentage reported as activity, at one dose (the size of the read-out at that dose, not a potency): 34.7%
Beside the measured number, compound 4's estimate is 5.3 percentage points above it; the range from low to high includes it.
By their numbers in this assay, from the lowest: compounds 4, 3 and 2 (each within the scatter of the next); then compound 1.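

With the rest of the molecule unchanged, placing benzyloxycarbonyl in position of the group of 5 heavy atoms (2 carbon, 3 nitrogen), on a saturated chain carbon, gives a number 17.7 percentage points lower from compound 1 to compound 4 (beyond the scatter) in this assay. Within the data shown here, this is the first single-place comparison in the set, and it shows that what this chain carries matters in this test, although compound 4 still gives 34.7% at the dose used. Nothing measured here explains the drop.

The swap changes several things at once, including ring content and the count of hydrogen-bond donors, so this single pair cannot show which of them matters. As far as these compounds go, how an amine, a carboxylic acid or a longer chain at this place would behave on the core of compound 1 remains open.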